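The compounds below may be only part of what the source reports. "The series", "measured", "known", "first", "only" and "open" are said of these compounds alone.

Measured in an assay on isolated protein for inhibition of leukotriene B4 receptor 1 (Homo sapiens), tested at 10 uM; on this read-out lower numbers stand for less inhibition and higher numbers for more inhibition at the one concentration tested (going by the name of the read-out):
compound 1 `CCc1cc(C(C)=O)c(O)cc1OCCCCCCC#N`, 103%
compound 2 `CSCc1cc(C(C)=O)c(O)cc1OCCCCCCC#N`, 97%
compound 3 `CC(=O)c1cc(CO)c(OCCCCCCC#N)cc1O`, 40%

Compound 1 gives the highest of these three numbers. One measured step is small, a number 6 percentage points lower from compound 1 to compound 2 (within the scatter), while two are large, a number 63 percentage points lower from compound 1 to compound 3 (beyond the scatter) and a number 57 percentage points lower from compound 2 to compound 3 (beyond the scatter). All three steps alter the group on a saturated chain carbon bound to an aromatic carbon, not the end of the chain.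

Compound 4 `CCc1cc(C(C)=O)c(O)cc1OCCCCCCS(C)(=O)=O` differs from compound 1 at that chain end: methylsulfonyl in place of cyano on a saturated chain carbon, six bonds along the chain from an oxygen on an aromatic ring. Going by the values given here, no measured step touches this position, so the measured steps bear on it only loosely; the high number of compound 1 in this assay leaves little room upward. A moderate downward step is expected, a number 23 percentage points lower from compound 1 to compound 4 (beyond the scatter), though one within the scatter is also plausible. Compound 4 is thus estimated at 80%, between 45% and 105%.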

Compound 4, a percentage reported as inhibition, at one concentration (the size of the read-out at that concentration, not a potency): 99%
Beside the measured number, compound 4's estimate is 19 percentage points below it; the range from low to high includes it.
By their numbers in this assay, from the lowest: compound 3; then compounds 2, 4 and 1 (each within the scatter of the next).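

Measured in this assay, the step from cyano to methylsulfonyl at the chain end is a number 4 percentage points lower from compound 1 to compound 4 (within the scatter) and so gives no sign of a real difference between the two groups. The earlier compounds shown here varied only the group on the chain carbon bound to an aromatic carbon, where hydroxy brought large steps; this change shows that the far end of the chain can carry a different group with the number staying high. Nothing available explains this result. Going by these compounds, whether an amine or a carboxylic acid at the chain end would keep the number high remains open, as does the effect of a shorter chain.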